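Shifting one chlorine on compound 3: what to expect

The source may hold more compounds than are shown below. What is called first, only, known or untested is meant among the compounds shown, and "the series" means these compounds.

Measured in a functional assay on A549 cells (Homo sapiens) for cytotoxicity, read by MTT assay, with a stated time of 72 h (a lower number here means a stronger inhibitor, a higher number a weaker inhibitor), so far
- compound 1 `Cn1ccc2c(Oc3ccc(NC(=O)c4cc5cccnc5n(-c5ccc(Br)cc5)c4=O)cc3)ncnc21` gives 52200 nM
- compound 2 `COc1ccc(-n2c(=O)c(C(=O)Nc3ccc(Oc4ncnc5c4ccn5C)cc3)cc3cccnc32)cc1` gives 83200 nM
- compound 3 `Cn1ccc2c(Oc3ccc(NC(=O)c4cc5cccnc5n(-c5ccc(C(F)(F)F)cc5Cl)c4=O)cc3)ncnc21` gives 364000 nM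

Compound 3 has the highest number of the three, which makes it the weakest inhibitor in this small set. Compounds 1 and 2 stand close together, with a 1.6-fold higher number from compound 1 to compound 2 (0.20 log units; within the scatter) between them.

Compound 4 `Cn1ccc2c(Oc3ccc(NC(=O)c4cc5cccnc5n(-c5ccc(C(F)(F)F)c(Cl)c5)c4=O)cc3)ncnc21` has not yet been measured. It has the same atoms as compound 3, joined differently, with 3-chloro-4-(trifluoromethyl)phenyl in place of 2-chloro-4-(trifluoromethyl)phenyl on an aromatic nitrogen.

Going by the values given here, no measured pair tests this change directly. The nearest evidence comes from two swaps of the group on that same nitrogen, which show a 7.0-fold higher number from compound 1 to compound 3 (0.84 log units; beyond the scatter) and a 4.4-fold higher number from compound 2 to compound 3 (0.64 log units; beyond the scatter). Both are modest, so this group can shift the number, but only compound 3 carries a chlorine there. With so little to go on, a modest step back towards compounds 1 and 2 is expected, though no real change would not surprise. The expected step is a 2.4-fold lower number from compound 3 to compound 4 (0.39 log units; beyond the scatter) in this assay, and it is only an estimate. For compound 4 the estimated value is 150000 nM, with an expected range from 50000 nM to 400000 nM.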

Compound 4, half-maximal inhibitory concentration: "not active" (no number reported)
For compound 4 the study gives words and no number, so the estimate cannot be set against anything.
By their numbers in this assay, from the lowest: compounds 1 and 2 (each within the scatter of the next); then compound 3.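

In this assay, going by these compounds alone, compound 4 is reported only in words, as not active, without a number, so no step from compound 3 to compound 4 can be read. On these data alone, how far 3-chloro-4-(trifluoromethyl)phenyl and 2-chloro-4-(trifluoromethyl)phenyl differ on that nitrogen stays open. Nothing shown offers an explanation for this result.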